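Pyridylmethyl positional isomer on the piperazine dithiocarbamate series

The source may report more compounds than this note shows. Statements on the series, on what has been measured and on what is new or still open speak of the compounds shown alone.

Measured so far in a functional assay on MGC-803 cells (Homo sapiens) for antiproliferative activity, read by CCK-8 assay, with a stated time of 72 h, tested at 8 uM; on this read-out lower numbers stand for a weaker effect and higher numbers for a stronger effect at the one concentration tested:
compound 1 `Nc1ccccc1NC(=O)c1ccc(CSC(=S)N2CCN(Cc3ccccn3)CC2)cc1` gives 65.2%
compound 2 `Nc1ccccc1NC(=O)c1ccc(CSC(=S)N2CCN(C(c3ccccc3)c3ccccc3)CC2)cc1` gives 9.9%
compound 3 `Nc1ccccc1NC(=O)c1ccc(CSC(=S)N2CCc3cc(Cl)ccc32)cc1` gives 82.2%

Compound 1 stands second of the three numbers in this assay. Compound 3 lies higher than compound 1 by a margin beyond the scatter, and compound 2 lies far lower, also beyond the scatter. Within the data shown here, no step between two measured compounds that differ in one place is available, so the effect of a single change at the saturated chain carbon bound to the amine nitrogen in the ring has not been read directly.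

Compound 4 `Nc1ccccc1NC(=O)c1ccc(CSC(=S)N2CCN(Cc3ccncc3)CC2)cc1` is the next member to be measured. Relative to compound 1 the change is pyridin-4-yl in place of pyridin-2-yl on a saturated chain carbon bound to an amine nitrogen in a ring. The two compounds have the same atoms joined differently, and the change moves only the ring nitrogen within a ring of the same size and composition.

Among the measured compounds shown here, for a change of this kind, with no matched step to lean on, the step from compound 1 to compound 4, expected as a number 5.2 percentage points lower from compound 1 to compound 4 (within the scatter), is estimated to be none beyond the scatter in this assay, with a slight lean downward. Compound 4 is therefore expected at 60%, within a range from 40% to 78%.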

Compound 4, a percentage reported as inhibition, at one concentration (the size of the read-out at that concentration, not a potency): 79.3%
Beside the measured number, compound 4's estimate is 19.3 percentage points below it; measured number outside the range, above it.
By their numbers in this assay, from the lowest: compound 2; then compound 1; then compounds 4 and 3 (each within the scatter of the next).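

In this assay the change from pyridin-2-yl to pyridin-4-yl on a saturated chain carbon bound to an amine nitrogen in a ring reads as a number 14.1 percentage points higher from compound 1 to compound 4 (beyond the scatter) and gives the series its first step between compounds that differ in one place. The two groups have the same atoms and the same counts, so the number at this position depends on where the ring nitrogen sits and not only on which ring is present. Nothing measured here bears on the reason for this step.

Where pyridin-3-yl would fall at the same place remains open, as does whether a plain phenyl ring there would hold the number of compound 4 79.3% or lose it. The step also rests on one concentration, so it says nothing about potency across a range of concentrations.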